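Thiophen-3-yl in place of 2-hydroxyphenyl: working notes

The source may hold more compounds than are shown below. What is called first, only, known or untested is meant among the compounds shown, and "the series" means these compounds.

Measured so far in a functional assay on HepG2 cells (Homo sapiens) for antiproliferative activity, read by MTT assay, with a stated time of 48 h; a higher number here means a weaker inhibitor, a lower number a stronger inhibitor:
- compound 1 `CC(=O)N1N=C(c2ccc3ccccc3c2)OC1c1ccc(Cl)cc1`: 1.88 ug/mL
- compound 2 `CC(=O)N1N=C(c2ccc3ccccc3c2)OC1c1ccccc1O`: 1.84 ug/mL

The values of compound 1 and compound 2 lie within the scatter of each other, so compound 2 holds no separate rank in this assay. Compound 3 `CC(=O)N1N=C(c2ccc3ccccc3c2)OC1c1ccsc1` carries thiophen-3-yl in place of 2-hydroxyphenyl on a saturated ring carbon. For the measured compounds named here, one measured step bears on this change, also on that saturated ring carbon: a 1.0-fold lower number from compound 1 to compound 2 (0.01 log units; within the scatter). Neither measured compound carries a five-membered aromatic ring, and the data do not test thiophen-3-yl directly. Going by the values given here, with that single step as the only guide, no step beyond the scatter is expected in this assay, in either direction. The estimate for compound 3 is 2.2 ug/mL, with an expected range of 1 ug/mL to 5 ug/mL. The estimated change is a 1.2-fold higher number from compound 2 to compound 3 (0.08 log units; within the scatter).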

Compound 3, half-maximal inhibitory concentration: 6.82 ug/mL
For compound 3 the middle estimate is 3.1-fold (0.49 log units) below the measured one; measured number outside the range, above it.
By their numbers in this assay, from the lowest: compounds 2 and 1 (each within the scatter of the next); then compound 3.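

In this assay this saturated ring carbon turns out to be sensitive to the group it carries: thiophen-3-yl raises the number in both available comparisons (a 3.7-fold higher number from compound 2 to compound 3 (0.57 log units; beyond the scatter); a 3.6-fold higher number from compound 1 to compound 3 (0.56 log units; beyond the scatter)), whereas 2-hydroxyphenyl and 4-chlorophenyl lie within the scatter of each other. Compound 1 has no hydroxy group yet stays with compound 2, so loss of the hydroxy group alone does not account for the higher number of compound 3. Nothing measured here gives a reason for the shift.

The compounds shown do not separate the change in ring size from the entry of the sulfur atom. They also leave open whether thiophen-2-yl, furan-3-yl or a phenyl ring bearing an amine would sit with compound 3 or with compound 1 and compound 2.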